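The source may hold more compounds than are shown below. What is called first, only, known or untested is meant among the compounds shown, and "the series" means these compounds.

Three compounds have been measured in a functional assay on 4T1 cells (Mus musculus) for cytotoxicity, read by MTT assay, with a stated time of 24 h; on this read-out lower numbers stand for stronger inhibition and higher numbers for weaker inhibition:

compound 1, `Cc1ccc(/C=C2\CN(C(=S)SCc3cn(Cc4ccc(F)cc4)nn3)C/C(=C\c3ccc(C)cc3)C2=O)cc1`, gives 29300 nM
compound 2, `Cc1ccc(/C=C2\CN(C(=S)SCc3cn(Cc4ccccc4F)nn3)C/C(=C\c3ccc(C)cc3)C2=O)cc1`, gives 28400 nM
compound 3, `O=C1/C(=C/c2ccccc2F)CN(C(=S)SCc2cn(Cc3ccccc3F)nn2)C/C1=C\c1ccccc1F`, gives 30700 nM

Compound 1 and compound 2 share one core and differ in a single place: 4-fluorophenyl in place of 2-fluorophenyl on a saturated chain carbon bound to an aromatic nitrogen. This change made a step of a 1.0-fold higher number from compound 2 to compound 1 (0.01 log units; within the scatter), so the two fluorine positions on that ring gave numbers that cannot be told apart here.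

Compound 3 has a different core, and the difference between the two cores is not broken down here. Its value sits beside those of compound 1 and compound 2, and all three numbers lie within the scatter of one another, so none of them can be called stronger or weaker.

The unmeasured compound 4, `O=C1/C(=C/c2ccccc2F)CN(C(=S)SCc2cn(Cc3ccc(F)cc3)nn2)C/C1=C\c1ccccc1F`, is built from the core of compound 3 by the same change that turns compound 2 into compound 1: 4-fluorophenyl in place of 2-fluorophenyl on a saturated chain carbon bound to an aromatic nitrogen. The place of the change is described in identical words for both pairs, so it is the same change on a different core.

Among the compounds with values here, the expected step from compound 3 to compound 4 in this assay is a 1.0-fold lower number from compound 3 to compound 4 (0.01 log units; within the scatter), because the only earlier instance of this change gave a 1.0-fold higher number from compound 2 to compound 1 (0.01 log units; within the scatter). On that basis compound 4 is estimated at 30000 nM, with a plausible range from 15000 nM to 60000 nM.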

Compound 4, half-maximal inhibitory concentration: 9900 nM
Beside the measured number, compound 4's estimate is 3.0-fold (0.48 log units) above it, outside the stated range (below it).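

In this assay, swapping 2-fluorobenzyl for 4-fluorobenzyl on the core of compound 3 gave a 3.1-fold lower number from compound 3 to compound 4 (0.49 log units; beyond the scatter) and so made a real difference on this core, although the step is modest in size. The same swap did not behave alike on the two cores, so the result from the core of compound 1 could not simply be carried over to the core of compound 3: the same change on two cores in this assay, a 1.0-fold higher number (0.01 log units; within the scatter) from compound 2 to compound 1 and a 3.1-fold lower number (0.49 log units; beyond the scatter) from compound 3 to compound 4, 3.2-fold (0.51 log units) apart, beyond the scatter of two such steps. This shows that the effect of moving the fluorine depends on the core it sits on, at least in these two pairs, but it does not show which feature of the cores is responsible, why the outcomes part, or what a third core would do, and two pairs are too few to support a general rule for the series.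

Still open, on these data alone, is what a benzyl group carrying no fluorine, or a 4-chlorobenzyl group, would give on a saturated chain carbon bound to an aromatic nitrogen on each of the two cores. As far as these compounds go, it is also open whether the 4-fluorobenzyl group would give a lower number than the 2-fluorobenzyl group on any further core.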